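Swapping a Propoxy Group for a Methyl Ester

A few compounds are considered here, and "the series" means these few. Any claim that something is new, unique, unknown or untested is made for them only; others in the source may bear on it.

Of the compounds shown here, two have been measured in a functional assay on DLD-1 cells (Homo sapiens) for antiproliferative activity, read by CellTiter-Glo, with a stated time of 72 h; on this read-out higher numbers stand for weaker inhibition and lower numbers for stronger inhibition. Compound 1 `CC1CCN(C2CCN(S(=O)(=O)c3cccnc3)CC2)CC1` gives 2400 nM in this assay, while compound 2 `CCCOc1ccc(S(=O)(=O)N2CCC(N3CCC(C)CC3)CC2)cc1` gives 452 nM, the lower of the two numbers and therefore the stronger inhibitor; the gap between them lies beyond the usual scatter.

Going by the values given here, the next compound, compound 3 `COC(=O)c1ccc(S(=O)(=O)N2CCC(N3CCC(C)CC3)CC2)cc1`, keeps the whole core of compound 2 and changes only one group on the aromatic ring: methoxycarbonyl in place of propoxy on an aromatic carbon. Among the compounds with values here, no pair of measured compounds shows this kind of change, so there is no direct guide to its effect. A moderate shift toward weaker inhibition seems the most plausible outcome, although a change within the scatter cannot be ruled out. Compound 3 is therefore expected to give about 900 nM in this assay, within a range of 300 nM to 3000 nM, an estimated step of a 2.0-fold higher number from compound 2 to compound 3 (0.30 log units; within the scatter).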

Compound 3, half-maximal inhibitory concentration: > 5000 nM
Compound 3 was reported as a limit; the forecaster's own chance of this, stated with the estimate: 5%; middle value at least 5.5-fold (0.74 log units) away from the limit.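

Going by these compounds alone, the swap of propoxy for methoxycarbonyl, on an aromatic carbon para to a large group, is the first change in one place that can be read in this assay, and it gives an at least 11-fold higher number from compound 2 to compound 3 (1.04 log units; beyond the scatter). This position is therefore not indifferent to the group it carries: the two groups hold the same number of heavy atoms and neither has a ring, yet they separate clearly. Compound 3 is reported only as a limit, so the step rests on that limit and not on an exact number: the limit of > 5000 nM in this assay, at which 1 of the 3 values shown sits.

Going by these compounds, with only these two groups compared at this position, it stays open whether the loss comes from adding the methyl ester or from removing the propoxy group. A carboxylic acid, a primary amide or a longer alkoxy chain such as butoxy at the same position could help separate these two readings.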